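The compounds below may be only part of what the source reports. "The series", "measured", "known", "first", "only" and "open" are said of these compounds alone.

Measured so far:
compound 1 `COc1ccc(/C=C/C(=O)c2ccc(NC(=O)CBr)cc2)cc1`, 42%
compound 2 `O=C(CO[N+](=O)[O-])Nc1ccc(C(=O)/C=C/c2ccc(Cl)cc2)cc1`, 57%

Both compounds were run in a functional assay on the whole organism (strain albino) for inhibition, with Rattus norvegicus as the target, read by paw edema, with stated times of 30 min and 2 h, at a dose of 100 mg/kg by the oral route; on this read-out higher numbers stand for more inhibition at the one dose given (going by the name of the read-out) and lower numbers for less inhibition. Compound 2 gives 57% and stands highest of the two numbers; its nearest neighbour is compound 1 with 42%, which lies beyond the scatter below it. Going by the values given here, no step between measured compounds differs in one place, so the two values show only that compound 2 is the higher one, not what any single change does.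

Compound 3 `COc1ccc(/C=C/C(=O)c2ccc(NC(=O)CO[N+](=O)[O-])cc2)cc1` is not yet measured. It differs from compound 2 as follows: methoxy in place of chloro on an aromatic carbon. Compound 3 carries the methoxy of compound 1 together with the rest of compound 2. Among the compounds with values here, no measured pair isolates this change, so the expected step in this assay is small and of uncertain direction, likely not beyond the scatter; the estimated step is a number 7 percentage points lower from compound 2 to compound 3 (within the scatter). Compound 3 is accordingly expected to give about 50%, within a range from 35% to 65%.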

Compound 3, a percentage reported as inhibition, in the whole organism at one dose (the size of the read-out at that dose, not a potency): 49%
Beside the measured number, compound 3's estimate is 1 percentage points above it, within the range that was stated.
By their numbers in this assay, from the lowest: compounds 1, 3 and 2 (each within the scatter of the next, the first and the last beyond it).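

In this assay, 4-chlorophenyl to 4-methoxyphenyl, on an aromatic carbon para to a large group, gives a number 8 percentage points lower from compound 2 to compound 3 (within the scatter), so with the nitrooxy chain in place this exchange of chloro for methoxy has no resolved effect on the read-out. Nitrooxy in place of bromo on the saturated chain carbon bound to a carbonyl carbon, with the 4-methoxyphenyl held constant, gives a number 7 percentage points higher from compound 1 to compound 3 (within the scatter), so the gap between compound 1 and compound 2 now divides into two single changes, neither resolved on its own. No measurement at hand accounts for either step.

Going by these compounds, whether an amine or a carboxylic acid in place of chloro on that aromatic carbon would give a step beyond the scatter remains open. Also open, on these data alone, is what a longer chain carrying the nitrooxy group would do.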